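A Fluoro Group Enters the Phenyl Ring of Compound 1

This account rests on a few compounds, and the source may have more. Where it says the series, first, only, none or still open, it means among the compounds named here.

Compound 1, `CC(=O)OC[C@H]1O[C@H](OC[C@@H](Cn2cc(CN(c3nc(-c4ccccc4)no3)C3CCCCC3)nn2)OC(C)=O)C=C[C@@H]1OC(C)=O`: in an ADME assay on RAW264.7 cells (Mus musculus) for cytotoxicity, read by MTT assay, with a stated time of 48 h (on this read-out higher numbers stand for lower toxicity in this test and lower numbers for higher toxicity in this test), compound 1 gives 28.6 ug/mL.
Compound 2, `C#CCN(c1nc(-c2ccc(Cl)cc2)no1)C1CCCCC1`: compound 2 gives 15.1 ug/mL.
Compound 3, `C#CCN(c1nc(-c2ccccc2)no1)C1CCCCC1`: compound 3 gives 32.1 ug/mL.

Compound 1 holds the second highest of the three numbers. Its value and that of compound 3 lie within the usual scatter of each other, and the gap to compound 2 also stays within that scatter, so none of the three can be set apart from the others on these numbers alone.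

Compound 4, `CC(=O)OC[C@H]1O[C@H](OC[C@@H](Cn2cc(CN(c3nc(-c4ccc(F)cc4)no3)C3CCCCC3)nn2)OC(C)=O)C=C[C@@H]1OC(C)=O`, differs from compound 1 by fluoro in place of hydrogen on an aromatic carbon. Among the compounds with values here, the one measured step that touches the same aromatic carbon is a 2.1-fold higher number from compound 2 to compound 3 (0.33 log units; beyond the scatter): there a chloro gave way to hydrogen and the number rose modestly. Read the other way, putting a halogen onto that carbon lowered the number. Fluoro is a different halogen, and no measured step shows fluoro itself, so the direction is suggested only by the chloro case.

Compound 4 is therefore expected to give a somewhat lower number than compound 1, possibly not beyond the scatter, estimated at 22 ug/mL with a range from 12 ug/mL to 40 ug/mL. This estimate means a 1.3-fold lower number from compound 1 to compound 4 (0.11 log units; within the scatter).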

Compound 4, half-maximal cytotoxic concentration: 31.5 ug/mL
For compound 4 the middle estimate is 1.4-fold (0.16 log units) below the measured one; the measured number falls inside the stated range.
By their numbers in this assay, from the lowest: compounds 2, 1, 4 and 3 (each within the scatter of the next, the first and the last beyond it).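

In this assay, fluoro in place of hydrogen on this aromatic carbon, para to a large group, gives a 1.1-fold higher number from compound 1 to compound 4 (0.04 log units; within the scatter), so this first look at fluoro at the position shows a step that stays within the scatter. Within the data shown here, the only other step at this carbon, with chloro leaving, is a 2.1-fold higher number from compound 2 to compound 3 (0.33 log units; beyond the scatter) and lies beyond the scatter, but that pair differs from compound 1 and compound 4 in the rest of the molecule as well as in the halogen, so the two steps show only that a halogen here need not be followed by a step beyond the scatter. Nothing available accounts for the difference between the two steps.

The compounds shown leave open whether chloro on the phenyl ring of compound 1, or fluoro on the phenyl ring of compound 3, would give a step beyond the scatter, which is what would separate the effect of the halogen from that of the rest of the molecule. They also leave open how a group of another kind on this carbon, such as an amine or a carboxylic acid, would read in this assay.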